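An Epoxide in Place of an Allylic Alcohol

This account rests on a few compounds, and the source may have more. Where it says the series, first, only, none or still open, it means among the compounds named here.

Compound 1 `C=CC(=C)[C@@H](O)C[C@H]1C(=C)CC[C@@H]2[C@]1(C)CCC[C@]2(C)C(=O)O` is a diterpenoid acid whose side chain carries a hydroxyl group and two double bonds. It was tested in a functional assay on A549 cells (Homo sapiens) for cytotoxicity, read by MTT assay, with a stated time of 48 h; on this read-out higher numbers stand for weaker inhibition and lower numbers for stronger inhibition. In this assay compound 1 gives > 40000 nM, which is a limit of the assay rather than a number. Compound 2 `C=CC(=C)CC[C@@H]1[C@@]2(C)CCC[C@](C)(COC(=O)/C=C/c3ccc(O)c(OC)c3)[C@@H]2CC[C@@]1(C)O`, a related structure bearing an ester, is the only one of the three measured compounds to return a number: in this assay compound 2 gives 16800 nM. Compound 3 `C=C/C(C)=C/C[C@H]1C(=C)CC[C@@H]2[C@]1(C)CCC[C@]2(C)C=O`, an aldehyde, also stops at a limit: in this assay compound 3 gives > 40000 nM. As far as these compounds go, compound 1 therefore stands at the limit of > 40000 nM in this assay, at which 2 of the 3 values shown sit, so its exact potency is unknown and can only be called weak.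

Compound 4 `C=C[C@]1(C)O[C@H]1C[C@H]1C(=C)CC[C@@H]2[C@]1(C)CCC[C@]2(C)C(=O)O` has not yet been measured. It differs from compound 1 in the side chain: a group of 6 heavy atoms (5 carbon, 1 oxygen; one three-membered non-aromatic ring with 1 hetero atom) in place of a group of 6 heavy atoms (5 carbon, 1 oxygen; no ring), on a saturated chain carbon bound to a saturated ring carbon. For the measured compounds named here, no pair of measured compounds differing in a single place is available, so there is no measured step to lean on. Because compound 1 sits at the limit of > 40000 nM in this assay, at which 2 of the 3 values shown sit, the expected step from compound 1 to compound 4 is a number no higher from compound 1 to compound 4 (the limit leaves the size open), at most modest in either direction. Compound 4 is expected to give about 40000 nM, within 15000 nM to 100000 nM, most likely again as a limit.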

Compound 4, half-maximal inhibitory concentration: > 40000 nM
Compound 4: a limit, no number; the forecaster's own chance of this, stated with the estimate: 65%; the middle value lies on the limit itself.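

In this assay, for the compounds shown here, compound 1 and compound 4 both stop at a limit, so no step between them can be read, because neither gives a number: the limit of > 40000 nM in this assay, at which 3 of the 4 values shown sit. The compounds shown leave open how strongly compound 1 and compound 4 really act on these cells, and whether the three-membered ring changes that at all.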